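The source may report more compounds than this note shows. Statements on the series, on what has been measured and on what is new or still open speak of the compounds shown alone.

Measured compounds:
- compound 1 `Fc1ccc(-c2cn3ccnc3c(-c3ccc4ncn(C5CCCCC5)c4c3)n2)cc1`: 33.3%
- compound 2 `COc1ccccc1-c1cn2ccnc2c(-c2ccc3ncn(C4CCCCC4)c3c2)n1`: 36.6%

In a functional assay on T47D cells (Homo sapiens) for inhibition, read by sulforhodamine B assay, with a stated time of 48 h, tested at 10 uM (a higher number here means more inhibition at the concentration tested (going by the name of the read-out), a lower number less inhibition), compound 1 gives 33.3% and compound 2 gives 36.6%. For the measured compounds named here, compound 2 stands at the top of these two numbers, but its only neighbour, compound 1, sits within the scatter of it: a number 3.3 percentage points higher from compound 1 to compound 2 (within the scatter).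

Compound 3 `c1csc(-c2cn3ccnc3c(-c3ccc4ncn(C5CCCCC5)c4c3)n2)c1` differs from compound 2 in one place: thiophen-2-yl in place of 2-methoxyphenyl on an aromatic carbon. Going by the values given here, the single measured step exchanged one six-membered aromatic ring of carbon only for another, and was small. Among the compounds with values here, no measured step exchanges such a ring for a five-membered aromatic ring with one hetero atom, so the data give no direct guide. With both measured compounds close together, no change beyond the scatter is expected, and the estimated step is a number 4.6 percentage points lower from compound 2 to compound 3 (within the scatter). For compound 3 the estimate is 32%, ranging from 12% to 52%.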

Compound 3, a percentage reported as inhibition, at one concentration (the size of the read-out at that concentration, not a potency): 70.3%
For compound 3 the middle estimate is 38.3 percentage points below the measured one, and the stated range ends below it.
By their numbers in this assay, from the lowest: compounds 1 and 2 (each within the scatter of the next); then compound 3.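

In this assay the group on this aromatic carbon, next to the ring nitrogen, proves able to change the read-out strongly: thiophen-2-yl in place of 2-methoxyphenyl gives a number 33.7 percentage points higher from compound 2 to compound 3 (beyond the scatter) and thiophen-2-yl in place of 4-fluorophenyl gives a number 37 percentage points higher from compound 1 to compound 3 (beyond the scatter) on the same core. The two six-membered aromatic rings stayed within the scatter of each other, so only the exchange for a five-membered aromatic ring with one hetero atom shows that this position responds to the kind of ring placed there. Nothing available explains why this exchange has so large an effect.

As far as these compounds go, it remains open whether the gain is specific to thiophen-2-yl, or would also appear with furan-2-yl, which has oxygen in place of sulfur, or with thiophen-3-yl. From the compounds shown here alone, whether this position needs an aromatic ring at all is also open, and a morpholine, an amine, could test that.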